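Swapping Dimethylamino for Methoxy on a Pentafluorinated Sulfonamide

This account rests on a few compounds, and the source may have more. Where it says the series, first, only, none or still open, it means among the compounds named here.

Three related compounds have been tested in a functional assay on SF-295 cells (Homo sapiens) for inhibition; on this read-out higher numbers stand for weaker inhibition of growth and lower numbers for stronger inhibition of growth. Compound 1 (`CN(C)c1ccc(NS(=O)(=O)c2c(F)c(F)c(F)c(F)c2F)cc1`) gives 501 nM. Compound 2 (`Cc1ccc(NS(=O)(=O)c2c(F)c(F)c(F)c(F)c2F)cc1C`) gives 479 nM, which is within the usual scatter of compound 1, so the two stand level. Compound 3 (`O=S(=O)(Nc1ccc2c(c1)OCCO2)c1c(F)c(F)c(F)c(F)c1F`) gives 54 nM, a number clearly lower than that of compound 1 and well beyond the scatter. Compound 1 therefore sits at the weak end of this small set, together with compound 2.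

The next compound, compound 4 (`COc1ccc(NS(=O)(=O)c2c(F)c(F)c(F)c(F)c2F)cc1`), keeps the core of compound 1 and changes one group: methoxy in place of dimethylamino on an aromatic carbon, para to a large group (methoxy in place of dimethylamino on an aromatic carbon). Among the measured compounds shown here, no two measured compounds differ in only one place, so no measured step offers a direct guide to this swap.

The only hint is indirect. Compound 3 also holds oxygen on the aromatic ring that carries the sulfonamide nitrogen, and compound 3 gives 54 nM. A moderate move toward stronger inhibition therefore seems likely, though this is an expectation from very few data. The expected step is a 2.5-fold lower number from compound 1 to compound 4 (0.40 log units; beyond the scatter). Compound 4 is estimated at 200 nM, with an expected range of 60 nM to 600 nM.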

Compound 4, concentration for 50% growth inhibition: 11 nM
Estimate against measurement, compound 4: 18-fold (1.26 log units) above, and the stated range ends above it.
By their numbers in this assay, from the lowest: compound 4; then compound 3; then compounds 2 and 1 (each within the scatter of the next).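

In this assay, methoxy in place of dimethylamino on an aromatic carbon, para to a large group, gives a 46-fold lower number from compound 1 to compound 4 (1.66 log units; beyond the scatter), so what sits at this position matters greatly for inhibition of growth. Among the compounds shown here, this is the first direct reading of a single change, as no earlier pair differed in only one place. The two groups match in their counts of hydrogen-bond donors and acceptors, neither has a ring or a net charge, and methoxy has only one heavy atom fewer, so these simple counts give little sign of how large the step would be. No measurement shown here explains why the swap has so large an effect.

On these data alone, it remains open whether the step reflects something particular to methoxy or mainly the departure of dimethylamino, a question that a hydroxyl, an ethoxy group or a chlorine atom on the same aromatic carbon could help to settle. One step also leaves open whether this swap would have a similar effect on a different core.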